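A few compounds are considered here, and "the series" means these few. Any claim that something is new, unique, unknown or untested is made for them only; others in the source may bear on it.

Compounds measured in a functional assay on MCF7 cells (Homo sapiens) for antiproliferative activity, read by MTT assay, with a stated time of 72 h; on this read-out lower numbers stand for stronger inhibition and higher numbers for weaker inhibition: compound 1 `COc1cc(CC(O)(COCc2ccccc2)COCc2ccccc2)nc(OC)n1` with > 100000 nM; compound 2 `COc1nc(CC(O)(COCc2ccccc2)COCc2ccccc2)c(C)c(OC)n1` with 4200 nM; compound 3 `COCn1c(CC(COCc2ccccc2)COCc2ccccc2)cc(=O)[nH]c1=O` with > 100000 nM.

The value of compound 1 is a limit of this assay and not a number. The value of compound 3 is likewise a limit of this assay. Going by the values given here, the one counted step, (methyl in place of hydrogen on an aromatic carbon), gives an at least 23-fold lower number from compound 1 to compound 2 (1.37 log units; beyond the scatter) in this assay. Compound 3 and compound 1 share the same atoms joined differently; the difference between the two cores is not broken down here.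

Compound 4 `COCn1c(CC(COCc2ccccc2)COCc2ccccc2)c(C)c(=O)[nH]c1=O` has not yet been measured. It arises from compound 3 by methyl in place of hydrogen on an aromatic carbon, the same kind of change as from compound 1 to compound 2, though the surroundings differ: in compound 4 the methyl sits ortho to a group of 1 heavy atom, meta to a methoxymethyl group and para to a group of 1 heavy atom, whereas in compound 2 it sits ortho to a methoxy group and para to a methoxy group. Given that compound 3 sits at the limit of > 100000 nM in this assay, at which 2 of the 3 values shown sit, the step from compound 3 to compound 4 is expected to be an at least 5.0-fold lower number from compound 3 to compound 4 (0.69 log units; beyond the scatter), resting on the single measured step and on the unknown starting point. Compound 4 is therefore estimated at 20000 nM, expected between 4000 nM and 100000 nM.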

Compound 4, half-maximal inhibitory concentration: 72600 nM
Beside the measured number, compound 4's estimate is 3.6-fold (0.56 log units) below it; measured number inside the range.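

Compound 3 stands at > 100000 nM in this assay, and this value is a limit of the assay and not a number. Methyl in place of hydrogen on an aromatic carbon gives an at least 1.3-fold lower number from compound 3 to compound 4 (0.13 log units; that floor lies within the scatter), so on this core the step can be read only as a floor, and that floor does not on its own show a change beyond the usual scatter. The pair therefore shows neither that the size of the first step carries over to the second core nor that it fails to, since the true size of the step on either core remains unknown: the same change on two cores in this assay, an at least 23-fold lower number (1.37 log units; beyond the scatter) from compound 1 to compound 2 and an at least 1.3-fold lower number (0.13 log units; that floor lies within the scatter) from compound 3 to compound 4; the limit leaves it open whether they differ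

The compounds shown leave open whether an ethyl group, a longer chain or a chlorine at this ring carbon would move the number further on either core. They also leave open how an amine or a carboxylic acid at the same place would read in this assay.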